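The compounds below may be only part of what the source reports. "The series", "measured", "known", "first", "only" and "open" are said of these compounds alone.

In an ADME assay on NIH3T3 cells (Mus musculus) for cytotoxicity, with a stated time of 72 h (a lower number here means a stronger inhibitor, a higher number a weaker inhibitor), compound 1 `OC[C@H]1O[C@@H](n2cnc3c(NCc4cccc(F)c4)ncnc32)[C@H](O)[C@@H]1O` gives 84000 nM. Compound 2 `OC[C@H]1O[C@@H](n2cnc3c(NCc4ccccc4Br)ncnc32)[C@H](O)[C@@H]1O` gives > 166000 nM, which is a limit of the assay and not a number. Compound 3 `OC[C@H]1O[C@@H](n2cnc3c(NCc4ccc(Cl)c(Cl)c4)ncnc32)[C@H](O)[C@@H]1O` has no number to start from, and its result stands as "not determined" (no result reported). Compound 4 `OC[C@H]1O[C@@H](n2cnc3c(NCc4ccc(F)c(Cl)c4)ncnc32)[C@H](O)[C@@H]1O` carries fluoro in place of chloro on an aromatic carbon, ortho to a chloro group and para to a large group (fluoro in place of chloro on an aromatic carbon). For the measured compounds named here, the one measured step, also an exchange of halogen on a phenyl group, is an at least 1.9-fold higher number from compound 1 to compound 2 (0.29 log units; that floor lies within the scatter), and it moves the halogen's position too. No size or direction of step from compound 3 can therefore be expected in this assay, so the expectation leans on compound 1 at 84000 nM. Compound 4 is estimated at 100000 nM, with an expected range from 40000 nM to 220000 nM.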

Compound 4, half-maximal inhibitory concentration: > 166000 nM
Compound 4: only a limit was reported; the forecaster's own chance of this, stated with the estimate: 35%; middle value at least 1.6-fold (0.22 log units) away from the limit.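

In this assay compound 4 gives > 166000 nM, which is a limit and not a number. The 3-chloro-4-fluorophenyl group, in place of 3-fluorophenyl, gives an at least 1.9-fold higher number from compound 1 to compound 4 (0.29 log units; that floor lies within the scatter), so this floor alone establishes no real change. The step between compound 2 and compound 4 cannot be read, because both stop at the same point: the limit of > 166000 nM in this assay, at which 2 of the 4 values shown sit.

On these data alone, with no result for compound 3, the exchange of chloro for fluoro itself stays open. Also open, as far as these compounds go, is whether a methoxy group or an amine at this place would give a readable number.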